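Replacing 4-methylphenyl on the carbonyl carbon

A few compounds are considered here, and "the series" means these few. Any claim that something is new, unique, unknown or untested is made for them only; others in the source may bear on it.

Values in a functional assay on ID8 cells (Mus musculus) for antiproliferative activity (a lower number here means a stronger inhibitor, a higher number a weaker inhibitor), for the measured compounds:
compound 1 (`O=C(Nc1ccc(O)c2c(=O)cc(-c3ccccc3Cl)oc12)c1ccccc1`) gives 13000 nM
compound 2 (`O=C(Nc1ccc(O)c2c(=O)cc(-c3ccccc3Cl)oc12)c1ccc(Cl)c(Cl)c1`) gives 13000 nM
compound 3 (`Cc1ccc(C(=O)Nc2ccc(O)c3c(=O)cc(-c4ccccc4Cl)oc23)cc1`) gives 16000 nM

The steps of a 1.2-fold higher number from compound 1 to compound 3 (0.09 log units; within the scatter) and a 1.2-fold higher number from compound 2 to compound 3 (0.09 log units; within the scatter) both stay within the scatter, so compound 3 sits level with the other two. The step of no change at the digits printed from compound 1 to compound 2 (within the scatter) also stays within the scatter.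

Compound 4 (`C[C@@H](NC(=O)OC(C)(C)C)C(=O)Nc1ccc(O)c2c(=O)cc(-c3ccccc3Cl)oc12`) carries 1-((tert-butoxycarbonyl)amino)ethyl in place of 4-methylphenyl on a carbonyl carbon. The measured steps bear on this only in part. They vary the substituents on a phenyl group at that carbonyl, and every measured compound keeps that aromatic ring, so no direct measure of its removal exists. The three steps give no direction for this assay and none reached beyond the scatter. On that basis, the expected step is a 1.1-fold lower number from compound 3 to compound 4 (0.03 log units; within the scatter) with a wide margin either way, as this change is larger than any measured so far. Compound 4 is estimated at 15000 nM (expected range 6000 nM to 40000 nM).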

Compound 4, half-maximal inhibitory concentration: 104000 nM
Compound 4: middle estimate off by 6.9-fold (0.84 log units), on the low side; measured number above the stated range.
By their numbers in this assay, from the lowest: compounds 1, 2 and 3 (each within the scatter of the next); then compound 4.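

In this assay, the carbonyl carbon now shows its first change beyond the scatter, and the shift holds against all three aryl amides (a 6.5-fold higher number from compound 3 to compound 4 (0.81 log units; beyond the scatter); an 8.0-fold higher number from compound 2 to compound 4 (0.90 log units; beyond the scatter); an 8.0-fold higher number from compound 1 to compound 4 (0.90 log units; beyond the scatter)). The earlier compounds shown here showed only that phenyl, 4-methylphenyl and 3,4-dichlorophenyl sit level at this position, whereas the open-chain 1-((tert-butoxycarbonyl)amino)ethyl group gives a weaker inhibitor than any of them. No measurement at hand accounts for this loss.

The compounds shown leave open whether the loss goes with removal of the aromatic ring or with the tert-butoxycarbonyl-protected chain itself, as compound 4 differs from the others in both respects. The free amine, with the tert-butoxycarbonyl group removed, and a benzyl group or a plain alkyl chain on the same carbonyl carbon, would separate these two readings.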